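Swapping the aryl group on the tetrazole nitrogen

This account rests on a few compounds, and the source may have more. Where it says the series, first, only, none or still open, it means among the compounds named here.

This account follows three measured compounds and one still untested in an ADME assay on HaCaT cells (Homo sapiens) for cytotoxicity, read by MTT assay, with a stated time of 72 h; on this read-out higher numbers stand for weaker inhibition and lower numbers for stronger inhibition. Compound 1 `COc1ccc(-n2nnnc2Nc2ccccc2Cl)cc1` gives 134000 nM in this assay. Compound 2 `COc1ccc(Nc2nnnn2-c2ccc(F)cc2)cc1` gives 101000 nM, and compound 3 `COc1ccc(Nc2nnnn2-c2ccccc2F)cc1` gives 122000 nM. Compound 1 sits at the upper end of these three numbers, yet its gaps to compound 3 and to compound 2 are both within the scatter, so the three compounds cannot be told apart on this read-out. Within the data shown here, the only single-point step among them, a 1.2-fold higher number from compound 2 to compound 3 (0.08 log units; within the scatter), also stays within the scatter.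

The untested compound 4 `COc1ccc(-n2nnnc2Nc2ccc(F)cc2)cc1` differs from compound 1 as follows: 4-fluorophenyl in place of 2-chlorophenyl on a nitrogen on an aromatic ring. Among the measured compounds shown here, no measured step changes the aryl group on the nitrogen of the core in exactly this way. For the measured compounds named here, the one step that does exchange a fluorophenyl for another, from compound 2 to compound 3, was within the scatter, and the whole set of compounds 1, 2 and 3 spans less than the scatter. On that basis the expected step of a 1.2-fold lower number from compound 1 to compound 4 (0.07 log units; within the scatter) is none beyond the scatter. Compound 4 is therefore estimated at 115000 nM in this assay, with a range of 60000 nM to 220000 nM.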

Compound 4, half-maximal inhibitory concentration: 155000 nM
For compound 4 the middle estimate is 1.3-fold (0.13 log units) below the measured one, and the stated range covers the measured number.
By their numbers in this assay, from the lowest: compounds 2, 3, 1 and 4 (each within the scatter of the next).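

In this assay, the exchange of 2-chlorophenyl for 4-fluorophenyl on a nitrogen on an aromatic ring gives a 1.2-fold higher number from compound 1 to compound 4 (0.06 log units; within the scatter), so this place on the core of compound 1 now has a step of its own, and that step stays within the scatter. Unlike the earlier fluorophenyl exchange, this one changes the halogen and its printed ring position together, and the read-out still does not separate the two compounds. Nothing measured alongside these numbers offers an explanation for this result.

The compounds shown leave open whether the halogen or its ring position matters on its own, since a 2-fluorophenyl or a 4-chlorophenyl on the core of compound 1 would be needed to take the two changes apart. Among these compounds, they also leave open whether any group at this place can move the number beyond the scatter, for instance a phenyl ring carrying a carboxylic acid or an amine, as every aryl group at this place so far carries a single halogen.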